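What one side-chain change may do to compound 2

A few compounds are considered here, and "the series" means these few. Any claim that something is new, unique, unknown or untested is made for them only; others in the source may bear on it.

Compound 1 `NCCCCCOc1ccc([C@H]2CC[C@]3(CC2)OOC2(O3)C3CC4CC(C3)CC2C4)cc1`: < 7 mL.min-1.g-1 (a limit of the assay)
Compound 2 `CC1(C)CC(O)(COc2ccc([C@H]3CC[C@]4(CC3)OOC3(O4)C4CC5CC(C4)CC3C5)cc2)CC(C)(C)N1`: 14 mL.min-1.g-1

Within the data shown here, in an ADME assay on microsomes from liver (Homo sapiens) for metabolic stability, read by LC-MS, tested at 1 uM (a lower number here means slower removal, a higher number faster removal of the compound), compound 2 gives 14 mL.min-1.g-1, the only actual number so far. Compound 1 gives < 7 mL.min-1.g-1, which is a limit of the assay and not a number.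

Compound 3 `O[C@H]1CC[C@H](NCCCOc2ccc([C@H]3CC[C@]4(CC3)OOC3(O4)C4CC5CC(C4)CC3C5)cc2)CC1` has not yet been measured. It departs from compound 2 as follows: 2-((4-hydroxycyclohexyl)amino)ethyl in place of 4-hydroxy-2,2,6,6-tetramethylpiperidin-4-yl on a saturated chain carbon bound to an oxygen on an aromatic ring. In words, 2-((4-hydroxycyclohexyl)amino)ethyl stands in place of 4-hydroxy-2,2,6,6-tetramethylpiperidin-4-yl on a saturated chain carbon bound to an oxygen on an aromatic ring.

Among the measured compounds shown here, one measured step bears on this place: an at least 2.0-fold higher number from compound 1 to compound 2 (0.30 log units; that floor lies within the scatter). In that step the same 4-hydroxy-2,2,6,6-tetramethylpiperidin-4-yl entered in place of 4-aminobutyl. Compound 3 gives that group up again, so on the strength of an at least 2.0-fold higher number from compound 1 to compound 2 (0.30 log units; that floor lies within the scatter) a small shift towards lower numbers in this assay is expected, but nothing beyond the scatter. The estimate means a 1.6-fold lower number from compound 2 to compound 3 (0.19 log units; within the scatter), which is an expected step and no more. For compound 3 the estimated value is 9 mL.min-1.g-1, with an expected range from 5 mL.min-1.g-1 to 18 mL.min-1.g-1.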

Compound 3, intrinsic clearance in microsomes in the liver assay: < 7 mL.min-1.g-1
Compound 3: no number, only a limit; the forecaster's own chance of this, stated with the estimate: 35%; middle value at least 1.2-fold (0.10 log units) away from the limit.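

In the liver assay, 2-((4-hydroxycyclohexyl)amino)ethyl in place of 4-hydroxy-2,2,6,6-tetramethylpiperidin-4-yl gives an at least 2.0-fold lower number from compound 2 to compound 3 (0.30 log units; that floor lies within the scatter). Among these compounds, a second, differently built side chain at this place, on a saturated chain carbon bound to an oxygen on an aromatic ring, thus joins compound 1 at the limit of the assay, which leaves compound 2 as the only compound with an actual number: the limit of < 7 mL.min-1.g-1 in the liver assay, at which 2 of the 3 values shown sit. In a physicochemical assay for solubility, read by nephelometry, measured as kinetic solubility, with a stated time of 30 min (a lower number here means a less soluble compound, a higher number a more soluble compound), compound 2 gives > 100 ug/mL, which is a limit of the assay. In the physicochemical assay compound 3 gives > 100 ug/mL, which is also a limit of the assay. In the physicochemical assay the change shows no readable effect, since compound 2 and compound 3 both give only a limit of the assay: the limit of > 100 ug/mL in the physicochemical assay, at which 2 of the 2 values shown sit.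

On these data alone, the steps that rest on two limits cannot be read, so how far compound 3 lies from compound 1 in the liver assay, and how far compound 3 lies from compound 2 in the physicochemical assay, stays open. The compounds shown also leave open how the ring and the chain length each count within this single change, and whether a carboxylic acid or a tertiary amine in place of the secondary amine of compound 3 would give an actual number in the liver assay.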